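A few compounds are considered here, and "the series" means these few. Any claim that something is new, unique, unknown or untested is made for them only; others in the source may bear on it.

For the measured compounds named here, compound 1 `c1ccc(CCCNC2CCc3ccsc3CC2)cc1` is the weakest of the three compounds measured so far in an assay on membranes from brain for displacement of a labelled ligand from Sigma non-opioid intracellular receptor 1 (Cavia porcellus), read by scintillation counting, with a stated time of 120 min (on this read-out lower numbers stand for stronger inhibition and higher numbers for weaker inhibition), where compound 1 gives 187 nM. Its nearest neighbour is compound 2 `c1ccc(CCCCNC2CCc3ccsc3CC2)cc1`, which in this assay gives 62 nM; the step of a 3.0-fold lower number from compound 1 to compound 2 (0.48 log units; beyond the scatter) is modest. Further off lies compound 3 `CCN(CCCc1ccccc1)C1CCc2ccsc2CC1`, which gives 17 nM, and the step of an 11-fold lower number from compound 1 to compound 3 (1.04 log units; beyond the scatter) is large.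

Compound 4 `Oc1ccc(-c2cc3c(s2)CCC(NCCCc2ccccc2)CC3)cc1` has not yet been measured. It differs from compound 1 by 4-hydroxyphenyl in place of hydrogen on an aromatic carbon, the new group sitting on an aromatic carbon of the five-membered ring of the shared core, next to the ring sulfur. Neither measured step bears on this change: both alter the amine or its chain, and nothing measured touches the aromatic core. The expectation for compound 4 therefore rests on compound 1 alone, and no step beyond the scatter is predicted in either direction, so the step of a 1.2-fold lower number from compound 1 to compound 4 (0.10 log units; within the scatter) is estimated with a wide band. In this assay compound 4 is expected to give about 150 nM, estimated between 30 nM and 750 nM.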

Compound 4, inhibition constant: 181 nM
Beside the measured number, compound 4's estimate is 1.2-fold (0.08 log units) below it; the measured number falls inside the stated range.
By their numbers in this assay, from the lowest: compound 3; then compound 2; then compounds 4 and 1 (each within the scatter of the next).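

For the compounds shown here, this is the first change on the aromatic core, as the earlier steps altered only the amine or its chain. In this assay, the step of a 1.0-fold lower number from compound 1 to compound 4 (0.01 log units; within the scatter) shows that 4-hydroxyphenyl in place of hydrogen on this aromatic carbon of the five-membered ring, next to the ring sulfur, leaves the number for compound 4 within the scatter of that for compound 1. Nothing available explains why this added ring goes with so small a step.

On these data alone, whether methyl, chlorine or an unsubstituted phenyl on the same carbon would also stay within the scatter remains open. As far as these compounds go, it is also open whether 4-hydroxyphenyl would behave in the same way alongside the ethyl group on the amine nitrogen of compound 3 or the longer chain of compound 2.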